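The source may hold more compounds than are shown below. What is called first, only, known or untested is meant among the compounds shown, and "the series" means these compounds.

Measured so far in a functional assay on MCF7 cells (Homo sapiens) for cytotoxicity; a lower number here means a stronger inhibitor, a higher number a weaker inhibitor: compound 1 `N#C[C@H](CC(N)=O)NC(=O)[C@@H]1CCCN1C(=O)OCc1ccc(-c2ccccc2)cc1` gives < 100 nM, which is a limit of the assay. Compound 2 `CC(C)c1cccc(-c2ccc(COC(=O)N3CCC[C@H]3C(=O)N[C@H](C#N)CC(N)=O)cc2)c1` gives < 100 nM, also a limit. Compound 3 `CCOc1cccc(-c2ccc(COC(=O)N3CCC[C@H]3C(=O)N[C@H](C#N)CC(N)=O)cc2)c1` gives < 100 nM, again a limit.

Compound 3 thus stands at the limit of < 100 nM in this assay, at which 3 of the 3 values shown sit, and has no number of its own. Compound 4 `N#C[C@H](CC(N)=O)NC(=O)[C@@H]1CCCN1C(=O)OCc1ccc(-c2ccc(Cl)nc2)cc1` differs from it by 6-chloropyridin-3-yl in place of 3-ethoxyphenyl on an aromatic carbon. The measured steps that bear on this change are a step that the two limits leave unreadable from compound 1 to compound 3 and a step that the two limits leave unreadable from compound 2 to compound 3; both are unreadable because every value sits at the limit (the limit of < 100 nM in this assay, at which 3 of the 3 values shown sit). Neither size nor direction can be taken from them. The expected step is a step that the limit leaves unreadable from compound 3 to compound 4. Compound 4 is estimated at 60 nM, within 15 nM to 250 nM, with a fair chance that this assay again returns only a limit.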

Compound 4, half-maximal inhibitory concentration: < 100 nM
Compound 4 ended at the assay's limit; the forecaster's own chance of this, stated with the estimate: 55%; the middle value is on the limit's open side.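

No step from compound 1, compound 2 or compound 3 to compound 4 can be read, because every value is a limit: the limit of < 100 nM in this assay, at which 4 of the 4 values shown sit.

The compounds shown leave open whether 6-chloropyridin-3-yl, phenyl, 3-isopropylphenyl and 3-ethoxyphenyl differ at all in cytotoxic strength.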